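A Swapped Aryl Group on the Sulfonyl Sulfur

A few compounds are considered here, and "the series" means these few. Any claim that something is new, unique, unknown or untested is made for them only; others in the source may bear on it.

Compound 1, `CCCCNC(=O)CCC(NS(=O)(=O)c1cc(C)ccc1Cl)C(=O)NCCCC`: 18%
Compound 2, `CCCCCCNC(=O)CCC(NS(=O)(=O)c1cc(C)ccc1Cl)C(=O)NCCCCCC`: 11.3%
Compound 3, `CCCCNC(=O)CCC(NS(=O)(=O)c1ccc(C)cc1C)C(=O)NCCCC`: 46.1%

Of the compounds shown here, three have been measured in a functional assay on IMR-32 cells (Homo sapiens) for cytotoxicity, read by MTT assay, tested at 60 ug/mL; on this read-out lower numbers stand for less inhibition and higher numbers for more inhibition at the one concentration tested (going by the name of the read-out). Compound 1 and compound 3 share one core and differ in a single place: 2,4-dimethylphenyl in place of 2-chloro-5-methylphenyl on a sulfonyl sulfur. That change gave a number 28.1 percentage points higher from compound 1 to compound 3 (beyond the scatter). Compound 2 is built on a different core, and how that core differs from the core of compound 1 is not broken down here; the two values alone show that compound 2 and compound 1 lie within the usual scatter of each other.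

Compound 4, `CCCCCCNC(=O)CCC(NS(=O)(=O)c1ccc(C)cc1C)C(=O)NCCCCCC`, has not yet been measured. It differs from compound 2 by 2,4-dimethylphenyl in place of 2-chloro-5-methylphenyl on a sulfonyl sulfur, and the place is described in the same words as for the earlier pair, so this is the same change made on the core of compound 2. In this assay, within the data shown here, the step is expected to be of similar size to the earlier one, because a number 28.1 percentage points higher from compound 1 to compound 3 (beyond the scatter) is the only guide available, so the expected step is a number 26.7 percentage points higher from compound 2 to compound 4 (beyond the scatter). Compound 4 is therefore estimated at 38%, most likely between 20% and 56%.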

Compound 4, a percentage reported as inhibition, at one concentration (the size of the read-out at that concentration, not a potency): 66%
Estimate against measurement, compound 4: 28 percentage points below; measured number above the stated range.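

In this assay, 2,4-dimethylphenyl in place of 2-chloro-5-methylphenyl on a sulfonyl sulfur gives a number 54.7 percentage points higher from compound 2 to compound 4 (beyond the scatter). The direction of the change carries over from one core to the other, but its size does not, as the two steps differ by more than repeated measurements would explain: the same change on two cores in this assay, a number 28.1 percentage points higher (beyond the scatter) from compound 1 to compound 3 and a number 54.7 percentage points higher (beyond the scatter) from compound 2 to compound 4, 26.6 percentage points apart, beyond the scatter of two such steps. These two pairs show that a step seen on one core in this series cannot simply be added to another core at the same size, but they do not show which part of the cores makes the difference or why, and two cores give no rule for a third.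

On these data alone, what a plain phenyl group on the sulfonyl sulfur would give on either core remains open. Also open, as far as these compounds go, is whether the step keeps growing with a longer chain on the amide nitrogens, or what happens with a carboxylic acid in place of an amide.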